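Stilbene-type Bile Acid Receptor Binders: From Thiazole to Chlorophenyl

The compounds below may be only part of what the source reports. "The series", "measured", "known", "first", "only" and "open" are said of these compounds alone.

Measured compounds:
Compound 1, `COC(=O)/C=C/c1cccc(N(Cc2ccc(/C=C/c3ccccn3)cc2)C(=O)C2CCCCC2)c1`, gives 309 nM in an assay on isolated protein with Bile acid receptor (Homo sapiens) as the target; on this read-out lower numbers stand for an effect already at smaller amounts and higher numbers for an effect only at larger amounts of compound.
Compound 2, `COC(=O)/C=C/c1cccc(N(Cc2ccc(/C=C/c3scnc3C)cc2)C(=O)C2CCCCC2)c1`, gives 227 nM in this assay.
Compound 3, `COC(=O)/C=C/c1cccc(N(Cc2ccc(/C=C/c3scnc3C)cc2)C(=O)C(C)C)c1`, gives 228 nM in this assay.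

Among these three numbers, compound 3 holds the second highest, but its separation from compound 2 is nil and its gap to compound 1 is within the scatter, so all three compounds read as equally potent here.

Compound 4, `COC(=O)/C=C/c1cccc(N(Cc2ccc(/C=C/c3cccc(Cl)c3)cc2)C(=O)C(C)C)c1`, is not yet measured. Its change from compound 3 is 3-chlorophenyl in place of 4-methyl-1,3-thiazol-5-yl on a double-bonded chain carbon bound to a double-bonded chain carbon. Within the data shown here, the one measured step that touches the same place is a 1.4-fold lower number from compound 1 to compound 2 (0.13 log units; within the scatter), where one small heteroaromatic ring was swapped for another without a change beyond the scatter. The other step, a 1.0-fold higher number from compound 2 to compound 3 (0.00 log units; within the scatter), shows the other end of the molecule tolerating a swap as well. Among the measured compounds shown here, compound 4 carries a six-membered ring of carbon only at that position, which no measured compound shows, so the expectation rests on tolerance alone. Compound 4 is therefore expected to give 200 nM, a step of a 1.1-fold lower number from compound 3 to compound 4 (0.06 log units; within the scatter), within a range of 70 nM to 600 nM.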

Compound 4, half-maximal effective concentration: 164 nM
Beside the measured number, compound 4's estimate is 1.2-fold (0.09 log units) above it, and the stated range covers the measured number.
By their numbers in this assay, from the lowest: compounds 4, 2, 3 and 1 (each within the scatter of the next).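

In this assay, the step of a 1.4-fold lower number from compound 3 to compound 4 (0.14 log units; within the scatter) shows that this place, on a double-bonded chain carbon bound to a double-bonded chain carbon, does not depend on a ring with hetero atoms. The earlier swap here only exchanged pyridin-2-yl for 4-methyl-1,3-thiazol-5-yl, both of them rings holding nitrogen, whereas 3-chlorophenyl is a six-membered aromatic ring of carbon only, with 0 hydrogen-bond acceptors against the 2 of the group it replaces, and the number stays within the scatter. No measurement shown here accounts for this tolerance.

The compounds shown leave open what a plain phenyl, a 4-chlorophenyl or a phenyl carrying an amine would give at this place, so the part played by the chlorine is unknown. Also open, going by these compounds, is how a carboxylic acid would read in place of the methyl ester at the other end of the molecule.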